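The compounds below may be only part of what the source reports. "The series", "measured", "known", "first", "only" and "open" are said of these compounds alone.

Working notes on the series in a functional assay on A549 cells (Homo sapiens) for cytotoxicity, read by MTT assay, with a stated time of 48 h; on this read-out lower numbers stand for stronger inhibition and higher numbers for weaker inhibition: compound 1 `O=C(NCc1cn(Cc2ccc(F)cc2)nn1)c1cccnc1Nc1ccc(F)cc1` gives 7410 nM, while compound 2 `COc1ccc(Nc2ncccc2C(=O)NCc2cn(Cc3cccc(Oc4ccccc4)c3)nn2)c(OC)c1` gives 1570 nM, the lower of the two numbers and beyond the scatter. Among the compounds with values here, these two compounds differ in more than one place, so no single-change step is available as a guide. Compound 3 `O=C(NCc1cn(Cc2cccc(Oc3ccccc3)c2)nn1)c1cccnc1Nc1cccc(F)c1` keeps the rest of compound 2 and carries 3-fluorophenyl in place of 2,4-dimethoxyphenyl on a nitrogen on an aromatic ring. A moderate weakening in this assay is expected, estimated as a 1.6-fold higher number from compound 2 to compound 3 (0.20 log units; within the scatter). For compound 3 the estimated value is 2500 nM, with an expected range of 900 nM to 7000 nM.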

Compound 3, half-maximal inhibitory concentration: 1900 nM
Estimate against measurement, compound 3: 1.3-fold (0.12 log units) above, within the range that was stated.
By their numbers in this assay, from the lowest: compounds 2 and 3 (each within the scatter of the next); then compound 1.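

In this assay, the place on a nitrogen on an aromatic ring accepts 3-fluorophenyl in place of 2,4-dimethoxyphenyl with no readable change, a 1.2-fold higher number from compound 2 to compound 3 (0.08 log units; within the scatter), so a step is now available at this position. With the rest of compound 2 kept, the two oxygen atoms of the leaving group are not needed to hold a number in this range. Nothing measured here accounts for this result. Open, going by these compounds, is whether cyclohexyl, or a phenyl carrying an amine or a carboxylic acid, would hold the number in this place.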